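Replacing 3,5-dichlorophenyl with 6-hydroxypyridin-3-yl

This account rests on a few compounds, and the source may have more. Where it says the series, first, only, none or still open, it means among the compounds named here.

In an ADME assay on A549 cells (Homo sapiens) for cytotoxicity, read by resazurin assay, with a stated time of 48 h (on this read-out higher numbers stand for lower toxicity in this test and lower numbers for higher toxicity in this test), compound 1 (`CN(C)c1ccc(NC(=O)c2cc(Cl)ccc2O)c(Cl)c1`) gives 85100 nM and compound 2 (`O=C(Nc1ccc(NCc2cc(Cl)cc(Cl)c2)cc1Cl)c1cc(Cl)ccc1O`) gives 13300 nM as the lower of the two numbers. That gap lies beyond the usual scatter of repeated measurements, so compound 2 is the more toxic of this pair. The two compounds differ in more than one place, however, so the gap cannot be tied to a single change.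

Compound 3 (`O=C(Nc1ccc(NCc2ccc(O)nc2)cc1Cl)c1cc(Cl)ccc1O`) differs from compound 2 in one place, on a saturated chain carbon bound to a nitrogen on an aromatic ring, where 6-hydroxypyridin-3-yl stands in place of 3,5-dichlorophenyl (6-hydroxypyridin-3-yl in place of 3,5-dichlorophenyl on a saturated chain carbon bound to a nitrogen on an aromatic ring). No single-change comparison has been measured yet, so the guidance is thin. For the measured compounds named here, the only hint is that compound 1, which has no 3,5-dichlorobenzyl group, gives 85100 nM as the higher number. A rise is therefore expected, with an estimated 3.0-fold higher number from compound 2 to compound 3 (0.48 log units; beyond the scatter) toward lower toxicity and beyond the scatter. In this assay the expected value for compound 3 is 40000 nM with a likely range from 15000 nM to 100000 nM across repeat measurements.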

Compound 3, half-maximal cytotoxic concentration: 98500 nM
Compound 3: middle estimate off by 2.5-fold (0.39 log units), on the low side, within the range that was stated.
By their numbers in this assay, from the lowest: compound 2; then compounds 1 and 3 (each within the scatter of the next).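

For the compounds shown here, this is the first single-change comparison at this position. In this assay, putting 6-hydroxypyridin-3-yl in place of 3,5-dichlorophenyl on a saturated chain carbon bound to a nitrogen on an aromatic ring gives a 7.4-fold higher number from compound 2 to compound 3 (0.87 log units; beyond the scatter), so this one change is enough to move the read-out toward lower toxicity in this test. Replacing dimethylamino with ((6-hydroxypyridin-3-yl)methyl)amino on an aromatic carbon gives a 1.2-fold higher number from compound 1 to compound 3 (0.06 log units; within the scatter), so these two groups cannot be told apart here, and the low number of compound 2 goes with 3,5-dichlorobenzyl rather than with every ring-bearing group in this place.

No measurement shown here accounts for the size of this step, so it stands as an observation only. On these data alone, it also remains open whether the step follows the loss of the two chlorine atoms or the arrival of the ring nitrogen and the hydroxy group; a plain benzyl group and a pyridin-3-ylmethyl group in the same place would help separate these two parts of the change.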